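The source may report more compounds than this note shows. Statements on the series, on what has been measured and on what is new or still open speak of the compounds shown alone.

Compound 1 `Cc1cccc(S(=O)(=O)c2ccc(CNC(=O)c3cc4cnccc4[nH]3)cc2)c1` — 32%
Compound 2 `O=C(NCc1ccc(S(=O)(=O)c2ccccc2)cc1)c1cnc2nccn2c1` — 30%
Compound 3 `O=C(NCc1ccc(S(=O)(=O)c2ccc(F)cc2)cc1)c1cc2cnccc2[nH]1` — 72%

All three compounds were tested in an ADME assay on microsomes from liver (Mus musculus) for metabolic stability, read by LC-MS, with a stated time of 30 min, tested at 1 uM; on this read-out lower numbers stand for a less stable compound and higher numbers for a more stable compound. Compound 3 stands highest of the three numbers. Compound 1 is its nearest neighbour, and the change from a 3-methylphenyl to a 4-fluorophenyl on the sulfonyl sulfur gave a number 40 percentage points higher from compound 1 to compound 3 (beyond the scatter). Among the compounds with values here, compound 2, with 30%, lies furthest from compound 3; it also carries a different core, so no single step links it to the other two.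

Compound 4 `O=C(NCc1ccc(S(=O)(=O)c2ccccc2)cc1)c1cc2cnccc2[nH]1` has not yet been measured in this assay. It differs from compound 3 in one place: hydrogen in place of fluoro on an aromatic carbon. Within the data shown here, only one measured step concerns the same ring on the sulfonyl sulfur, the large rise from compound 1 to compound 3, which shows that this ring can move the number a long way. Compound 2 carries a plain phenyl on its sulfonyl sulfur and sits low, but on another core, so it is only a hint. Taking the fluoro away from compound 3 is therefore expected to give a step downward beyond the scatter, a number 30 percentage points lower from compound 3 to compound 4 (beyond the scatter). For compound 4 the estimate in this assay is 42%, with a range from 22% to 65%.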

Compound 4, percent of the compound remaining: 54%
Beside the measured number, compound 4's estimate is 12 percentage points below it; the measured number falls inside the stated range.
By their numbers in this assay, from the lowest: compounds 2 and 1 (each within the scatter of the next); then compound 4; then compound 3.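

In this assay, within the data shown here, the plain phenyl gives the first reading of the fluoro on its own: taking that one atom away leaves a number 18 percentage points lower from compound 3 to compound 4 (beyond the scatter) with nothing else altered. The earlier large jump on this ring can now be seen in two parts, since hydrogen in place of methyl gives a number 22 percentage points higher from compound 1 to compound 4 (beyond the scatter) and the fluoro adds the remainder, so losing the methyl and gaining the fluoro each go with a more stable compound here. With the phenyl held the same, changing only the group on the carbonyl carbon gives a number 24 percentage points higher from compound 2 to compound 4 (beyond the scatter). The low number of compound 2 goes with its core. Its plain phenyl is shared with compound 4.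

On these data alone, whether a chloro or a methoxy group in place of the fluoro would give a higher or lower number than the fluoro does, and whether the 4-fluorophenyl would lift the core of compound 2 by a similar amount, stays open. Nothing shown here says why any of these changes moves the number.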